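The source may hold more compounds than are shown below. What is called first, only, known or untested is meant among the compounds shown, and "the series" means these compounds.

Measured compounds:
- compound 1, `CC(=O)Oc1ccccc1C(=O)O[C@H]1CO[C@H]2[C@@H]1OC[C@H]2OC(=O)c1snnc1C`: 0.0065 h
- compound 2, `CCC(=O)O[C@@H]1CO[C@H]2[C@@H]1OC[C@@H]2OC(=O)c1ccccc1OC(C)=O`: 0.011 h
- compound 3, `CCCCC(=O)O[C@@H]1CO[C@H]2[C@@H]1OC[C@@H]2OC(=O)c1ccccc1OC(C)=O`: 0.0117 h

These values come from an ADME assay on a cell-free system (plasma, Homo sapiens) for metabolic stability, with Plasma (Rattus norvegicus) as the target, read by HPLC, at pH 7.4; a lower number here means that the compound disappears faster, a higher number that the compound lasts longer. Among the three, compound 1 has the lowest number, but its neighbours sit close: a 1.7-fold higher number from compound 1 to compound 2 (0.23 log units; within the scatter) and a 1.8-fold higher number from compound 1 to compound 3 (0.26 log units; within the scatter), and between the other two a 1.1-fold higher number from compound 2 to compound 3 (0.03 log units; within the scatter). All three compounds share the same core and the same second acid part; they differ only in the group on one carbonyl carbon.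

Compound 4, `CC(=O)Nc1cccc(C(=O)O[C@@H]2CO[C@H]3[C@@H]2OC[C@@H]3OC(=O)c2ccccc2OC(C)=O)c1`, changes that same group once more: 3-acetamidophenyl in place of 4-methyl-1,2,3-thiadiazol-5-yl on a carbonyl carbon

Within the data shown here, the steps that bear on this are the two already made at that carbonyl carbon, both within the scatter, even though they swapped the 4-methyl-1,2,3-thiadiazol-5-yl group for quite different alkyl chains. Among the measured compounds shown here, no measured step shows what an aromatic ring carrying an acetamido group does here. So the expected step in this assay is a 1.7-fold higher number from compound 1 to compound 4 (0.23 log units; within the scatter), none beyond the scatter. Compound 4 is therefore estimated at 0.011 h, with a range from 0.004 h to 0.03 h.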

Compound 4, half-life: 0.0583 h
The estimate for compound 4 lay 5.3-fold (0.72 log units) below the measured number; measured number outside the range, above it.
By their numbers in this assay, from the lowest: compounds 1, 2 and 3 (each within the scatter of the next); then compound 4.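

In this assay the group on this carbonyl carbon can move the number beyond the scatter: 3-acetamidophenyl gives a 9.0-fold higher number from compound 1 to compound 4 (0.95 log units; beyond the scatter) in place of 4-methyl-1,2,3-thiadiazol-5-yl, then a 5.3-fold higher number from compound 2 to compound 4 (0.72 log units; beyond the scatter) in place of ethyl and a 5.0-fold higher number from compound 3 to compound 4 (0.70 log units; beyond the scatter) in place of butyl. The three earlier groups, one aromatic and two alkyl, stayed within the scatter of one another, so among these four groups only 3-acetamidophenyl stands apart. Nothing measured here explains this step.

From the compounds shown here alone, it remains open whether the step comes from the benzene ring itself or from the acetamido group on it, a question that a plain phenyl group at the same carbonyl carbon could address. Going by these compounds, whether an amine or a carboxylic acid on that ring would give a similar number also remains unknown.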